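The compounds below may be only part of what the source reports. "The series", "measured", "known", "first", "only" and "open" are said of these compounds alone.

Within the data shown here, compound 3 `CCOc1cccc(-c2ccc(C(=O)NC(/C=C/c3ccccc3)C(Cc3cccc(C(=N)N)c3)C(=O)OC)cc2)c1` gives 3600 nM in an assay on isolated protein (Oryctolagus cuniculus) for inhibition of Trypsin (Homo sapiens) (a higher number here means a weaker inhibitor, a lower number a stronger inhibitor), the highest of the three numbers measured so far, although its gap to compound 2 `COC(=O)C(Cc1cccc(C(=N)N)c1)C(/C=C/c1ccccc1)NC(=O)c1ccc(-c2ccc(OC)cc2OC)cc1` with 2900 nM and to compound 1 `COC(=O)C(Cc1cccc(C(=N)N)c1)C(/C=C/c1ccccc1)NC(=O)c1ccc(-c2cccc(OC)c2)cc1` with 2200 nM stays within the scatter. Compound 4 `CCOc1ccc(-c2ccc(C(=O)NC(/C=C/c3ccccc3)C(Cc3cccc(C(=N)N)c3)C(=O)OC)cc2)cc1` differs from compound 3 by a single change: 4-ethoxyphenyl in place of 3-ethoxyphenyl on an aromatic carbon. Two measured steps also shifted the substitution on this outer ring: a 1.3-fold higher number from compound 1 to compound 2 (0.12 log units; within the scatter) and a 1.2-fold higher number from compound 2 to compound 3 (0.09 log units; within the scatter), and neither left the scatter. On that basis compound 4 is expected to show no shift beyond the scatter, a 1.0-fold lower number from compound 3 to compound 4 (0.01 log units; within the scatter). In this assay compound 4 is therefore estimated at 3500 nM, with a range from 1500 nM to 8000 nM.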

Compound 4, half-maximal inhibitory concentration: 2800 nM
Compound 4: the middle estimate sits 1.3-fold (0.10 log units) above what was measured; the measured number falls inside the stated range.
By their numbers in this assay, from the lowest: compounds 1, 4, 2 and 3 (each within the scatter of the next).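

Among these compounds, the swap of 3-ethoxyphenyl for 4-ethoxyphenyl, the first change here that keeps the same atoms and rearranges them only, stays within the scatter (a 1.3-fold lower number from compound 3 to compound 4 (0.11 log units; within the scatter)). The steps to the other two outer rings also stay within it (a 1.0-fold lower number from compound 2 to compound 4 (0.02 log units; within the scatter)) and (a 1.3-fold higher number from compound 1 to compound 4 (0.10 log units; within the scatter)), so all four substitution patterns read alike. No supporting evidence bears on this result.

From the compounds shown here alone, whether an amine, a carboxylic acid or a longer chain on this outer ring would move the number beyond the scatter remains open.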